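Phenyl for Pyridin-2-yl on Two Different Cores

The compounds below may be only part of what the source reports. "The series", "measured", "known", "first", "only" and "open" are said of these compounds alone.

Measured so far in an assay on isolated protein for inhibition of Hematopoietic prostaglandin D synthase (Homo sapiens), read by fluorescence polarization; a lower number here means a stronger inhibitor, a higher number a weaker inhibitor:
compound 1 `CC(C)(O)c1nc(-c2cccc(CNC(=O)c3cnc(-c4ccccn4)nc3)c2)no1` gives 7.48 nM
compound 2 `CC(C)(O)c1nc(-c2cccc(CNC(=O)c3cnc(-c4ccccc4)nc3)c2)no1` gives 7.18 nM
compound 3 `c1ccc(-c2ncc(-c3cnc(-c4ccccn4)nc3)[nH]2)cc1` gives 1770 nM

Compound 2 differs from compound 1 by phenyl in place of pyridin-2-yl on an aromatic carbon and the step is a 1.0-fold lower number from compound 1 to compound 2 (0.02 log units; within the scatter). Compound 3 rests on a different core; how its core differs from that of compound 1 is not broken down here, but its number in this assay is far higher than those of compound 1 and compound 2. Compound 4 `c1ccc(-c2ncc(-c3cnc(-c4ccccc4)[nH]3)cn2)cc1` repeats on compound 3 the change already seen: phenyl in place of pyridin-2-yl on an aromatic carbon, at a place described in the same words as before, so it is the same change. Because a 1.0-fold lower number from compound 1 to compound 2 (0.02 log units; within the scatter) lies within the scatter, the step from compound 3 to compound 4 is expected to be about a 1.0-fold lower number from compound 3 to compound 4 (0.02 log units; within the scatter). Compound 4 is therefore estimated at 1700 nM in this assay, between 700 nM and 4500 nM.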

Compound 4, half-maximal inhibitory concentration: 8.88 nM
Estimate against measurement, compound 4: 190-fold (2.28 log units) above; the measured number lies below the stated range.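

In this assay, phenyl in place of pyridin-2-yl did not carry over from one core to the other, since the step on the core of compound 3 is a 200-fold lower number from compound 3 to compound 4 (2.30 log units; beyond the scatter) and is large. The two steps do not agree: the same change on two cores in this assay, a 1.0-fold lower number (0.02 log units; within the scatter) from compound 1 to compound 2 and a 200-fold lower number (2.30 log units; beyond the scatter) from compound 3 to compound 4, 190-fold (2.28 log units) apart, beyond the scatter of two such steps. This shows that, across these four compounds, the size of the step depends on the core, but it does not show which part of either core is responsible or what the same change would do on a third core.

Going by these compounds, it remains open whether a morpholine or an amine at the same place would behave as on the core of compound 1 or as on the core of compound 3. On these data alone, it is also open which of these two results a further core would follow.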